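The compounds below may be only part of what the source reports. "The series", "measured", "known", "first", "only" and "open" are said of these compounds alone.

Three amides built on the shared core of compound 1 `CCC(CC)C(=O)Nc1c(C(O)(C(F)(F)F)C(F)(F)F)ccc2ccccc12` have been measured in an assay on LtK cells with ATP-sensitive inward rectifier potassium channel 11 (Homo sapiens) as the target; on this read-out lower numbers stand for an effect already at smaller amounts and higher numbers for an effect only at larger amounts of compound. Compound 1 gives 4340 nM. Compound 2 `O=C(Nc1c(C(O)(C(F)(F)F)C(F)(F)F)ccc2ccccc12)c1ccccc1` gives 44 nM, and compound 3 `Cc1ccccc1C(=O)Nc1c(C(O)(C(F)(F)F)C(F)(F)F)ccc2ccccc12` gives 5550 nM, the highest of the three numbers; compound 1 lies close to compound 3, while compound 2 lies far from it. The step of a 99-fold lower number from compound 1 to compound 2 (1.99 log units; beyond the scatter) was large, the step of a 1.3-fold higher number from compound 1 to compound 3 (0.11 log units; within the scatter) stayed within the scatter, and the step of a 130-fold higher number from compound 2 to compound 3 (2.10 log units; beyond the scatter) was large.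

Compound 4 `N#Cc1cccc(C(=O)Nc2c(C(O)(C(F)(F)F)C(F)(F)F)ccc3ccccc23)c1` differs from compound 3 by 3-cyanophenyl in place of 2-methylphenyl on a carbonyl carbon. This change removes the methyl that separates compound 2 from compound 3 and brings in a nitrile on the ring. The step of a 130-fold higher number from compound 2 to compound 3 (2.10 log units; beyond the scatter) bears on it most directly: the methyl alone raised the number greatly, so taking it away is expected to lower it by a comparable amount. Among the compounds with values here, no measured compound carries a nitrile, so what that group adds is unknown and widens the range. Compound 4 is therefore expected to show a 56-fold lower number from compound 3 to compound 4 (1.74 log units; beyond the scatter) in this assay, landing near compound 2. The estimate for compound 4 is 100 nM, within a range of 20 nM to 700 nM.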

Compound 4, half-maximal effective concentration: 12 nM
Compound 4: middle estimate off by 8.3-fold (0.92 log units), on the high side; measured number below the stated range.
By their numbers in this assay, from the lowest: compound 4; then compound 2; then compounds 1 and 3 (each within the scatter of the next).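

In this assay, the step of a 3.7-fold lower number from compound 2 to compound 4 (0.56 log units; beyond the scatter) is modest but beyond the scatter, so the nitrile of the 3-cyanophenyl does more than restore the unsubstituted phenyl's number: it lowers that number further. Among the compounds shown, a substituent on this aromatic ring can therefore move the number either way, up with the methyl of compound 3 and down with the nitrile of compound 4. The full exchange gives a 460-fold lower number from compound 3 to compound 4 (2.67 log units; beyond the scatter) and, measured against the pentan-3-yl amide, the step of a 360-fold lower number from compound 1 to compound 4 (2.56 log units; beyond the scatter) places compound 4 lowest of the four, with all of its steps beyond the scatter, though nothing measured here accounts for the effect of the nitrile.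

Going by these compounds, what remains open is whether the change belongs to the group or to its place, since both differ between compound 3 and compound 4; a 3-methylphenyl or a 2-cyanophenyl on the same carbonyl carbon would separate the two. On these data alone, it is also open whether a chlorine, a methoxy group or a carboxylic acid in place of the nitrile would give a similar number.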